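A few compounds are considered here, and "the series" means these few. Any claim that something is new, unique, unknown or untested is made for them only; others in the source may bear on it.

Measured in a functional assay on OCI-Ly10 cells (Homo sapiens) for cytotoxicity, read by CCK-8 assay, with a stated time of 72 h; on this read-out lower numbers stand for stronger inhibition and higher numbers for weaker inhibition:
Compound 1 `Cn1cc(NC(=O)c2cnc3ccc(N[C@@H]4CCCNC4)nn23)c(C(F)F)n1`: 700 nM
Compound 2 `Cn1cc(NC(=O)c2cnc3ccc(N[C@@H]4CCNC4)nn23)c(C(F)F)n1`: 3600 nM

Of these two, compound 1 has the lower number, 700 nM. Compound 3 `Cn1cc(NC(=O)c2cnc3ccc(N[C@@H]4CCCNC4)nn23)c(C#N)n1` departs from it by cyano in place of difluoromethyl on an aromatic carbon. Among the measured compounds shown here, the only measured step, a 5.1-fold higher number from compound 1 to compound 2 (0.71 log units; beyond the scatter), puts pyrrolidin-3-yl in place of piperidin-3-yl elsewhere in the molecule. It therefore serves only as a guide to size, and no measurement tests this exchange directly. A modest move toward a higher number is expected in this assay, namely a 2.1-fold higher number from compound 1 to compound 3 (0.33 log units; beyond the scatter). The expected value for compound 3 is 1500 nM, with an estimated range of 500 nM to 4500 nM.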

Compound 3, half-maximal inhibitory concentration: 5800 nM
The estimate for compound 3 lay 3.9-fold (0.59 log units) below the measured number; the whole stated range lies below it.
By their numbers in this assay, from the lowest: compound 1; then compounds 2 and 3 (each within the scatter of the next).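

In this assay, putting cyano in place of difluoromethyl gives an 8.3-fold higher number from compound 1 to compound 3 (0.92 log units; beyond the scatter), so this carbon of the five-membered aromatic ring is sensitive to the group it carries. This single exchange leaves compound 3 within the scatter of compound 2, which carries its own single change elsewhere in the molecule. Nothing available explains the shift. From the compounds shown here alone, it remains open how trifluoromethyl, methyl or a chlorine atom would fare at this carbon, and whether cyano would have the same effect alongside pyrrolidin-3-yl.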